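The source may report more compounds than this note shows. Statements on the series, on what has been measured and on what is new or still open speak of the compounds shown alone.

Measured in an ADME assay on microsomes from liver (Mus musculus) for metabolic stability; a higher number here means faster removal of the compound, a lower number slower removal:
- compound 1 `COc1ccc(S(=O)(=O)Nc2ccc(CN3CCN(C(=O)C4CN(C(C)=O)C4)CC3)cc2)cc1`: 1 mL.min-1.g-1
- compound 2 `COc1ccc(S(=O)(=O)Nc2ccc(CN3CCN(C(=O)C4CCCN(C)C4)CC3)cc2)cc1`: 1.5 mL.min-1.g-1

Only these two compounds have been measured, and compound 2, at 1.5 mL.min-1.g-1, lies within the scatter of compound 1. Within the data shown here, the next compound, compound 3 `COc1ccc(S(=O)(=O)Nc2ccc(CN3CCN(C(=O)C4CC(O)(C(F)(F)F)C4)CC3)cc2)cc1`, has no measurement yet. Its change from compound 2 is 3-hydroxy-3-(trifluoromethyl)cyclobutyl in place of 1-methylpiperidin-3-yl on a carbonyl carbon. In words, 3-hydroxy-3-(trifluoromethyl)cyclobutyl stands in place of 1-methylpiperidin-3-yl on a carbonyl carbon.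

Among the measured compounds shown here, one measured step bears on this exchange, as it also concerns the group on a carbonyl carbon. There, 1-methylpiperidin-3-yl replaces 1-acetylazetidin-3-yl, giving a 1.5-fold higher number from compound 1 to compound 2 (0.18 log units; within the scatter). For the measured compounds named here, no measured compound carries 3-hydroxy-3-(trifluoromethyl)cyclobutyl, so this single step offers only weak guidance. Going by the step to compound 2, a change beyond the scatter is not expected in this assay, and no direction can be named. The expected step is no change at the digits printed from compound 2 to compound 3 (within the scatter). For compound 3 the estimated value is 1.5 mL.min-1.g-1, with an expected range of 0.7 mL.min-1.g-1 to 4 mL.min-1.g-1.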

Compound 3, intrinsic clearance in microsomes: 8 mL.min-1.g-1
Compound 3: middle estimate off by 5.3-fold (0.73 log units), on the low side, outside the stated range (above it).
By their numbers in this assay, from the lowest: compounds 1 and 2 (each within the scatter of the next); then compound 3.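

In this assay the group on the carbonyl carbon now shows that it can move the number: 3-hydroxy-3-(trifluoromethyl)cyclobutyl in place of 1-methylpiperidin-3-yl gives a 5.3-fold higher number from compound 2 to compound 3 (0.73 log units; beyond the scatter) while the earlier pair had shown no step beyond the scatter at this place. The same group in place of 1-acetylazetidin-3-yl gives an 8.0-fold higher number from compound 1 to compound 3 (0.90 log units; beyond the scatter) and so both measured starting points lead to faster removal with this group, while the two nitrogen-bearing rings stay within the scatter of each other. No measurement at hand accounts for this rise.

The compounds shown leave open whether the rise follows the hydroxy group, the trifluoromethyl group or the four-membered carbon ring itself, and a plain cyclobutyl or a 3-hydroxycyclobutyl on the same carbonyl carbon would separate these. Going by these compounds, it also remains open how a group of another kind at this place, such as a carboxylic acid or an open-chain amine, would stand in this assay.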